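Swapping 4-Methylphenyl for 3-Chlorophenyl on the Shared Core

A few compounds are considered here, and "the series" means these few. Any claim that something is new, unique, unknown or untested is made for them only; others in the source may bear on it.

Measured compounds:
Compound 1 `Cc1nc(-c2ccsc2)sc1COc1ccc2c(c1)OCC2CC(=O)O` gives 56.5%
Compound 2 `Cc1cccc(-c2nc(C)c(COc3ccc4c(c3)OCC4CC(=O)O)s2)c1` gives 47.2%
Compound 3 `Cc1ccc(-c2nc(C)c(COc3ccc4c(c3)OCC4CC(=O)O)s2)cc1` gives 54.9%

All three were tested in a functional assay on CHO cells for agonist activity at Free fatty acid receptor 1 (Homo sapiens), read by FLIPR and calcium flux, tested at 100 nM; on this read-out lower numbers stand for a weaker effect and higher numbers for a stronger effect at the one concentration tested. They share one core and differ only in the aromatic group attached to it. Compound 3 stands second highest of the three numbers; it lies nearest compound 1, with a number 1.6 percentage points lower from compound 1 to compound 3 (within the scatter), and furthest from compound 2, with a number 7.7 percentage points higher from compound 2 to compound 3 (within the scatter). Both of these steps, like a number 9.3 percentage points lower from compound 1 to compound 2 (within the scatter), stay within the scatter, so the three measured compounds cannot be ranked against each other.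

Compound 4 `Cc1nc(-c2cccc(Cl)c2)sc1COc1ccc2c(c1)OCC2CC(=O)O` has not yet been measured. It differs from compound 3 in one place: 3-chlorophenyl in place of 4-methylphenyl on an aromatic carbon.

Within the data shown here, no measured step exchanges a methyl group for chlorine. The closest guidance comes from the measured exchanges of the aromatic group itself: thiophen-3-yl to 3-methylphenyl, thiophen-3-yl to 4-methylphenyl, and 3-methylphenyl to 4-methylphenyl, all of which stayed within the scatter. On that basis the step of a number 2.9 percentage points lower from compound 3 to compound 4 (within the scatter) is expected to stay within the scatter as well, with no clear direction. Compound 4 is therefore estimated to give 52%, in a range from 36% to 66%.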

Compound 4, a percentage reported as activity, at one concentration (the size of the read-out at that concentration, not a potency): 43%
Estimate against measurement, compound 4: 9 percentage points above; the measured number falls inside the stated range.
By their numbers in this assay, from the lowest: compounds 4, 2, 3 and 1 (each within the scatter of the next, the first and the last beyond it).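

In this assay, among these compounds, this position on the five-membered ring, next to the ring nitrogen and the ring sulfur, now shows steps beyond the scatter, which no step among the earlier compounds did: a number 11.9 percentage points lower from compound 3 to compound 4 (beyond the scatter) and a number 13.5 percentage points lower from compound 1 to compound 4 (beyond the scatter) are both read from exchanges of the whole aromatic group. Among the compounds shown here, the one exchange that keeps the group's printed ring position, chloro in place of methyl on the phenyl ring, gives a number 4.2 percentage points lower from compound 2 to compound 4 (within the scatter) and so shows no separation, which means that chlorine cannot be singled out as what sets compound 4 apart from compound 3, since that step also moves the substituent from the 4-position to the 3-position of the phenyl group. No measured evidence bears on what lies behind these steps.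

A 4-chlorophenyl group would give the missing single exchange of methyl for chloro against compound 3, and would show whether the chlorine behaves differently at the two phenyl positions. From the compounds shown here alone, how a methoxy group or an amine on the phenyl ring would read out here also stays open, and the single tested concentration leaves potency itself unresolved.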